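The source may hold more compounds than are shown below. What is called first, only, known or untested is meant among the compounds shown, and "the series" means these compounds.

Measured so far in a functional assay on CHO cells for agonist activity at 5-hydroxytryptamine receptor 4 (Homo sapiens), read by a luciferase reporter and cAMP accumulation, with a stated time of 4 h; on this read-out lower numbers stand for smaller maximal responses and higher numbers for larger maximal responses:

compound 1 `CC(C)c1nc(-c2nnc(C3CCN(C4CCC4)CC3)o2)c2ccccn12` gives 55%
compound 2 `CC(C)c1nc(-c2nnc(C3CCN(CC4CCC4)CC3)o2)c2ccccn12` gives 63%
compound 3 `CC(C)c1nc(-c2nnc(C3CCN(C(C)C)CC3)o2)c2ccccn12` gives 65%

Compound 3 holds the highest of the three numbers, yet nothing separates it from the others beyond the scatter: the nearest is compound 2 with a number 2 percentage points higher from compound 2 to compound 3 (within the scatter), the furthest is compound 1 with a number 10 percentage points higher from compound 1 to compound 3 (within the scatter).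

Compound 4 `COCCCN1CCC(c2nnc(-c3nc(C(C)C)n4ccccc34)o2)CC1` differs from compound 3 in one place: 3-methoxypropyl in place of isopropyl on an amine nitrogen in a ring.

All three measured steps bear on this position, since each of them exchanges the group on the amine nitrogen in the ring. Cyclobutylmethyl in place of cyclobutyl gave a number 8 percentage points higher from compound 1 to compound 2 (within the scatter); isopropyl in place of cyclobutyl gave a number 10 percentage points higher from compound 1 to compound 3 (within the scatter); isopropyl in place of cyclobutylmethyl gave a number 2 percentage points higher from compound 2 to compound 3 (within the scatter). None of these left the scatter, so the maximal response in this assay has so far been insensitive to what sits on that nitrogen. Among the compounds with values here, no measured compound carries a chain with an oxygen at this position, so the 3-methoxypropyl group is a step into untested ground; still, on the evidence of the three measured steps no change beyond the scatter is expected, in either direction, and the expected step is a number 4 percentage points lower from compound 3 to compound 4 (within the scatter).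

Compound 4 is therefore estimated at 61%, with a range from 47% to 75%.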

Compound 4, largest response reached (Emax), in percent of the reference or control that the assay uses: 67%
For compound 4 the middle estimate is 6 percentage points below the measured one, within the range that was stated.
By their numbers in this assay, from the lowest: compounds 1, 2, 3 and 4 (each within the scatter of the next, the first and the last beyond it).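

In this assay, within the data shown here, the 3-methoxypropyl group is the only group on the amine nitrogen in a ring so far that carries an oxygen, with 5 heavy atoms entering for 3, and the read-out gives a number 2 percentage points higher from compound 3 to compound 4 (within the scatter) and, against the cyclobutylmethyl compound, a number 4 percentage points higher from compound 2 to compound 4 (within the scatter), so this chain with a hydrogen-bond acceptor stands level with the purely carbon groups isopropyl and cyclobutylmethyl. Among these compounds, the first step to leave the scatter is a number 12 percentage points higher from compound 1 to compound 4 (beyond the scatter), a modest one, which separates the 3-methoxypropyl group from the cyclobutyl group directly on that nitrogen, while compound 2 and compound 3 remain within the scatter of both. Nothing available gives a reason for this modest separation.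

Compound 4 differs from compound 3 in both chain length and oxygen, so a plain butyl or pentyl chain would be needed to tell which of the two goes with the number. Also open, on these data alone, is whether a longer ether chain, or a chain ending in an amine or a carboxylic acid, would stay within the scatter of compound 4 in this assay as well.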